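Replacing One Fluoro With Hydrogen

The source may hold more compounds than are shown below. What is called first, only, known or untested is meant among the compounds shown, and "the series" means these compounds.

In a functional assay on BT-474 cells (Homo sapiens) for inhibition, read by CellTiter-Glo, with a stated time of 72 h (a lower number here means a stronger inhibitor, a higher number a weaker inhibitor), compound 1 `Cc1cc(Nc2ncnc3cc(O)c(NC(=O)/C=C/[C@H]4CCCN4C)cc23)ccc1Oc1cnc2ccnn2c1` gives 3.11 nM and compound 2 `C=C(F)C(=O)Nc1cc2c(Nc3ccc(Oc4cc5nncn5cn4)c(C)c3)ncnc2cc1OCC` gives 3.88 nM so these two numbers lie within the usual scatter of each other. Compound 2 therefore stands level with compound 1 on the evidence so far, even though their structures differ in several places.

Compound 3 `C=CC(=O)Nc1cc2c(Nc3ccc(Oc4cc5nncn5cn4)c(C)c3)ncnc2cc1OCC` differs from compound 2 in one place (hydrogen in place of fluoro on a double-bonded chain carbon bound to a carbonyl carbon) with hydrogen in place of fluoro on a double-bonded chain carbon bound to a carbonyl carbon. Among the measured compounds shown here, no measured pair shows what this swap does on its own, so the data offer no direct guide to its effect. The expected outcome is a 1.3-fold lower number from compound 2 to compound 3 (0.11 log units; within the scatter) as a step that stays within the scatter. Compound 3 is estimated at 3 nM with an expected range of 1 nM to 9 nM in this assay once it is measured.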

Compound 3, half-maximal inhibitory concentration: 4.69 nM
For compound 3 the middle estimate is 1.6-fold (0.19 log units) below the measured one, and the stated range covers the measured number.
By their numbers in this assay, from the lowest: compounds 1, 2 and 3 (each within the scatter of the next).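

Among the compounds shown here, this is the first comparison that changes a single place. In this assay, replacing 1-fluoroethenyl with vinyl gives a 1.2-fold higher number from compound 2 to compound 3 (0.08 log units; within the scatter). At this position, on a double-bonded chain carbon bound to a carbonyl carbon, the fluoro can therefore be exchanged for hydrogen with no reading beyond the usual scatter of the cell measurement, and no other data here help to explain this result.

Going by these compounds, this single pair compares only fluoro and hydrogen on that carbon, so it remains open whether a chlorine atom, a methyl group or a nitrile there would also leave the number level. On these data alone, it also remains open whether the same exchange would behave alike on a different core, such as that of compound 1.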